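Swapping Methyl for Bromo in Compound 2

The source may report more compounds than this note shows. Statements on the series, on what has been measured and on what is new or still open speak of the compounds shown alone.

Compound 1 `O=C1/C(=C/c2cccnc2)CN(S(=O)(=O)c2ccc(Br)cc2)C/C1=C\c1ccccc1C(F)(F)F`: 5510 nM
Compound 2 `Cc1ccc(S(=O)(=O)N2C/C(=C\c3ccncc3)C(=O)/C(=C/c3ccccc3C(F)(F)F)C2)cc1`: 5090 nM

Both compounds were tested in a functional assay on QGY-7703 cells (Homo sapiens) for cytotoxicity, read by MTT assay, with a stated time of 24 h; a higher number here means a weaker inhibitor, a lower number a stronger inhibitor. The values of compound 2 and compound 1 lie within the usual scatter of each other, so neither stands apart from the other on these numbers. The two compounds differ in more than one place, so they do not isolate any single change.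

Compound 3 `O=C1/C(=C/c2ccncc2)CN(S(=O)(=O)c2ccc(Br)cc2)C/C1=C\c1ccccc1C(F)(F)F` departs from compound 2 in one place only, bromo in place of methyl on an aromatic carbon, para to a large group. The 4-methylphenyl thus becomes 4-bromophenyl, the group also carried by compound 1. Among the measured compounds shown here, no measured pair shows this change alone. The closest guide is that compound 1 with 4-bromophenyl gives 5510 nM and compound 2 with 4-methylphenyl gives 5090 nM. On that basis, no step beyond the scatter is expected in this assay. The expected change is small, a 1.0-fold higher number from compound 2 to compound 3 (0.01 log units; within the scatter). For compound 3 the estimated value is 5200 nM, with an expected range from 2800 nM to 9500 nM.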

Compound 3, half-maximal inhibitory concentration: 7060 nM
Estimate against measurement, compound 3: 1.4-fold (0.13 log units) below; measured number inside the range.
By their numbers in this assay, from the lowest: compounds 2, 1 and 3 (each within the scatter of the next).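

In this assay, the exchange of 4-methylphenyl for 4-bromophenyl now stands alone as a measured pair, and bromo in place of methyl on the aromatic carbon para to a large group gives a 1.4-fold higher number from compound 2 to compound 3 (0.14 log units; within the scatter) on this single pair, so that at this position the two groups cannot be told apart in this cell assay. Compound 3 also provides a second single change, pyridin-4-yl in place of pyridin-3-yl on the double-bonded chain carbon, which gives a 1.3-fold higher number from compound 1 to compound 3 (0.11 log units; within the scatter) and likewise does not separate the two compounds on these numbers. No measurement available here offers any explanation for either step, so the two results stand only as numbers.

The three compounds leave open whether a different group at this aromatic carbon, such as a methoxy group, an amine or a carboxylic acid, would move the number beyond the scatter. From the compounds shown here alone, it also remains open whether pyridin-2-yl on the double-bonded chain carbon, or a phenyl ring in place of the pyridine, would do so.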